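A few compounds are considered here, and "the series" means these few. Any claim that something is new, unique, unknown or untested is made for them only; others in the source may bear on it.

In an in vivo ADME assay on the whole organism (strain BALB/c) for pharmacokinetics, with Mus musculus as the target, read by LC-MS, at a dose of 5 mg/kg by the oral route (a higher number here means that a larger share of the oral dose reaches the circulation, a lower number that a smaller share of the oral dose reaches the circulation), compound 3 `CC(C)c1ccc(S(C)(=O)=O)cc1C#Cc1cc(Cl)ccc1OCC(=O)O` gives 29%. Compound 1 `CC(C)c1ccc(S(C)(=O)=O)cc1C#Cc1cc(C#N)ccc1OCC(=O)O` gives 26%, within the scatter of compound 3. Compound 2 `CC(C)S(=O)(=O)c1ccc(Cl)c(C#Cc2cc(Cl)ccc2OCC(=O)O)c1` gives 64%, beyond the scatter of both, which leaves compound 3 in the lower pair of the three.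

Compound 4 `CS(=O)(=O)c1ccc(Cl)c(C#Cc2cc(Cl)ccc2OCC(=O)O)c1` differs from compound 3 by one change, chloro in place of isopropyl on an aromatic carbon, para to a methylsulfonyl group (chloro in place of isopropyl on an aromatic carbon). Within the data shown here, the only measured step, a number 3 percentage points higher from compound 1 to compound 3 (within the scatter), is chloro in place of cyano at another place, so it offers little guidance here. Among the measured compounds shown here, compound 2 is the only measured compound with chloro on that carbon, but it also carries a different sulfonyl group from compound 4, which makes it a partial guide. Resting on compound 2 at 64%, a rise in this assay is expected, with wide uncertainty, and the expected step is a number 16 percentage points higher from compound 3 to compound 4 (beyond the scatter). For compound 4 the estimated value is 45%, with an expected range of 22% to 70%.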

Compound 4, oral bioavailability: 141%
The estimate for compound 4 lay 96 percentage points below the measured number; the measured number lies above the stated range.
By their numbers in this assay, from the lowest: compounds 1 and 3 (each within the scatter of the next); then compound 2; then compound 4.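

In this assay, the aromatic carbon para to a methylsulfonyl group proves highly responsive: chloro in place of isopropyl there gives a number 112 percentage points higher from compound 3 to compound 4 (beyond the scatter), whereas the earlier step, chloro in place of cyano at another place, stayed within the scatter. The sulfonyl sulfur emerges as a second responsive place, as methyl in place of isopropyl on it gives a number 77 percentage points higher from compound 2 to compound 4 (beyond the scatter). Nothing among the data shown accounts for either step.

The compounds shown leave open how a methoxy or trifluoromethyl group on that aromatic carbon, or an ethyl or cyclopropyl group on the sulfonyl sulfur, would read. Also open, as far as these compounds go, is whether the two changes add up, since each step is read with the other place held at a single group.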